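A Bromine Added Twice, Weaker Once, Expected Weaker Again

The source may report more compounds than this note shows. Statements on the series, on what has been measured and on what is new or still open speak of the compounds shown alone.

Compound 1 `Cc1ccc(-c2nnc(SCC(=O)c3ccccc3)o2)c(O)c1` is the reference point. In a functional assay on MCF7 cells (Homo sapiens) for cytotoxicity, read by MTT assay and propidium iodide staining, with a stated time of 24 h (on this read-out lower numbers stand for stronger inhibition and higher numbers for weaker inhibition), compound 1 gives 150 nM. Compound 3 `Cc1ccc(-c2nnc(SCC(=O)c3ccc(Br)cc3)o2)c(O)c1` differs from compound 1 in a single place: bromo in place of hydrogen on an aromatic carbon. In this assay compound 3 gives 2070 nM, so the move from compound 1 to compound 3 produced a 14-fold higher number from compound 1 to compound 3 (1.14 log units; beyond the scatter), a clear loss of cytotoxic potency from one change.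

Compound 2 `O=C(CSc1nnc(-c2cccc3ccccc23)o1)c1ccccc1` carries a different core; how its core differs from that of compound 1 is not broken down here. In this assay compound 2 gives 230 nM, a number that sits close to that of compound 1, within the usual scatter, while the gap between compound 2 and compound 3 lies beyond it.

Compound 4 `O=C(CSc1nnc(-c2cccc3ccccc23)o1)c1ccc(Br)cc1` is not yet measured. It stands to compound 2 exactly as compound 3 stands to compound 1: bromo in place of hydrogen on an aromatic carbon. The surroundings of the change are described in the same words in both pairs, so this is the same change carried onto a new core.

Because the same change gave a 14-fold higher number from compound 1 to compound 3 (1.14 log units; beyond the scatter), compound 4 is expected to suffer a step in the same direction, estimated at an 11-fold higher number from compound 2 to compound 4 (1.04 log units; beyond the scatter), though with a single precedent the size remains uncertain. Compound 4 is therefore expected to give 2500 nM in this assay, estimated to fall between 800 nM and 8000 nM.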

Compound 4, half-maximal inhibitory concentration: 260 nM
Estimate against measurement, compound 4: 9.6-fold (0.98 log units) above; the measured number lies below the stated range.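

In this assay, the same swap on the second core gives a 1.1-fold higher number from compound 2 to compound 4 (0.05 log units; within the scatter), so the phenyl to 4-bromophenyl change that cost so much potency on the core of compound 1 leaves no change that can be told apart from ordinary repeat variation on the core of compound 2. Among the compounds shown here, the effect of this change therefore did not carry from one core to the other with its size intact, and a step seen on one core proved a poor guide to the step on the other: the same change on two cores in this assay, a 14-fold higher number (1.14 log units; beyond the scatter) from compound 1 to compound 3 and a 1.1-fold higher number (0.05 log units; within the scatter) from compound 2 to compound 4, 12-fold (1.09 log units) apart, beyond the scatter of two such steps What this does not show is which part of the two cores decides the outcome, or why, and with only one pair on each core it cannot establish a general rule for either core.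

As far as these compounds go, it remains open whether another group in the place of the bromo, such as chloro, methoxy, an amine or a carboxylic acid, would behave as the bromo does in compound 3 or as it does in compound 4. Also open, from the compounds shown here alone, is whether a third core would side with the first pair or the second.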